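The source may hold more compounds than are shown below. What is called first, only, known or untested is meant among the compounds shown, and "the series" means these compounds.

Compound 1 `CCCc1cc(C(C)=O)c(O)cc1OCCCCC#N` and compound 2 `CCCc1cc(C(C)=O)c(O)cc1OCCCCC(=O)O` share a core and differ only at the far end of the chain attached to the ring oxygen. In an assay on isolated protein for inhibition of leukotriene B4 receptor 1 (Homo sapiens), tested at 10 uM (a lower number here means less inhibition, a higher number more inhibition at the concentration tested (going by the name of the read-out)), compound 1 gives 84%, while compound 2 gives 11%, the lowest of the two numbers; the step of a number 73 percentage points lower from compound 1 to compound 2 (beyond the scatter) corresponds to carboxy in place of cyano. Compound 3 `CCCc1cc(C(C)=O)c(O)cc1OCCCCCC(=O)O` is not yet measured. Against compound 2 the change is carboxymethyl in place of carboxy on a saturated chain carbon, four bonds along the chain from an oxygen on an aromatic ring, so the acid end simply sits further out along the chain. For the measured compounds named here, none of the measured steps bears on such a lengthening: the only known step, a number 73 percentage points lower from compound 1 to compound 2 (beyond the scatter), exchanges one end group for another rather than stretching the chain, so it gives no direction for this case. The expected step of a number 4 percentage points higher from compound 2 to compound 3 (within the scatter) is therefore judged small, not beyond the scatter. Compound 3 is estimated at 15%, within a range of 0% to 45%.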

Compound 3, a percentage reported as inhibition, at one concentration (the size of the read-out at that concentration, not a potency): 73%
The estimate for compound 3 lay 58 percentage points below the measured number; the measured number lies above the stated range.
By their numbers in this assay, from the lowest: compound 2; then compound 3; then compound 1.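

In this assay, carboxymethyl in place of carboxy gives a number 62 percentage points higher from compound 2 to compound 3 (beyond the scatter), so at this position the distance of the acid from the shared core matters, not only which end group the chain carries. An acid at the chain end therefore does not by itself go with a low number: carboxymethyl in place of cyano gives only a modest step, a number 11 percentage points lower from compound 1 to compound 3 (beyond the scatter). Nothing available explains why this small lengthening has so large an effect.

From the compounds shown here alone, whether a longer chain such as 2-carboxyethyl or 3-carboxypropyl would raise the number further or lower it again remains open. Going by these compounds, it is also open whether a nitrile on the longer chain, or an amide or ester at its end, would behave like compound 3.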